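Swapping the amide aryl group on the shared core

A few compounds are considered here, and "the series" means these few. Any claim that something is new, unique, unknown or untested is made for them only; others in the source may bear on it.

Three compounds have been measured in a functional assay on Huh-7 cells (Homo sapiens) for inhibition, read by MTT assay, with a stated time of 48 h; a lower number here means a stronger inhibitor, a higher number a weaker inhibitor:
Compound 1 `COc1ccc2c(=O)c(/C=C/C(=O)Nc3cc(C)ccc3C)coc2c1` — 11100 nM
Compound 2 `O=C(/C=C/c1coc2cc(O)ccc2c1=O)NCc1ccccc1` — 4690 nM
Compound 3 `Cc1ccc(CNC(=O)/C=C/c2coc3cc(O)ccc3c2=O)cc1` — > 100000 nM

Among the two numbers available, compound 1 has the highest value; compound 2 sits nearest to it with the lower number, and that gap lies beyond the usual scatter. For compound 3 the result in this assay is a limit rather than a number (the limit of > 100000 nM in this assay, at which 1 of the 3 values shown sits).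

Among the compounds with values here, the one measured step, an at least 21-fold higher number from compound 2 to compound 3 (1.32 log units; beyond the scatter), involves a methyl in place of hydrogen on an aromatic carbon and is large. It concerns a different part of the amide substituent than the change now considered, so it bears on it only loosely.

Compound 4 `CCOc1ccc(NC(=O)/C=C/c2coc3cc(OC)ccc3c2=O)cc1` differs from compound 1 by 4-ethoxyphenyl in place of 2,5-dimethylphenyl on an amide-type nitrogen. Within the data shown here, no measured pair shows this exchange of one aryl group for another on the amide nitrogen, so the direction of the step cannot be read from the data. He therefore expects a step of modest size, a 1.2-fold lower number from compound 1 to compound 4 (0.09 log units; within the scatter), and estimates for compound 4 a value of 9000 nM in this assay, within a range from 3000 nM to 30000 nM.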

Compound 4, half-maximal inhibitory concentration: 3230 nM
Beside the measured number, compound 4's estimate is 2.8-fold (0.45 log units) above it; the measured number falls inside the stated range.
By their numbers in this assay, from the lowest: compounds 4 and 2 (each within the scatter of the next); then compound 1. At a limit, above all of these: compound 3.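

The exchange shows that the aryl group on the amide nitrogen matters in this assay: the step is a 3.4-fold lower number from compound 1 to compound 4 (0.54 log units; beyond the scatter), and it lies beyond the usual scatter. Within the data shown here, this is the first measured exchange of one aryl group for another at this place, and the first step towards a lower number, whereas the only earlier step, an at least 21-fold higher number from compound 2 to compound 3 (1.32 log units; beyond the scatter), ran the other way and concerned a different part of the amide substituent. The entering 4-ethoxyphenyl brings a hydrogen-bond acceptor that the leaving 2,5-dimethylphenyl lacks, but nothing at hand tells which feature of the exchange accounts for the step.

The compounds shown leave open whether the lower number depends on the ethoxy group itself, or would persist with a longer alkoxy chain, an amine or a carboxylic acid on the same aromatic ring. They also leave open whether the same exchange would move the number in the same direction on a core carrying the hydroxyl group of compound 2 rather than the methoxy group of compound 1.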